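Replacing the oxygen substituent, from compound 2 to compound 3

This account rests on a few compounds, and the source may have more. Where it says the series, first, only, none or still open, it means among the compounds named here.

Going by the values given here, in a functional assay on FM3A cells (Mus musculus) for cytotoxicity (on this read-out higher numbers stand for an effect only at larger amounts of compound and lower numbers for an effect already at smaller amounts), compound 2 `COOC1(OOC(C)(C)OC)CCCCCCCCCCC1` gives 7300 nM as the lowest number so far. Compound 1 `COOC1(OOCCCCCCI)CCCCCCCCCCC1` stands higher at 86000 nM on the same read-out. Compound 3 `COOC1(OOCCCCCC(=O)O)CCCCCCCCCCC1` carries 5-carboxypentyl in place of 1-methoxy-1-methylethyl on an oxygen and so has a chain more like the 6-iodohexyl of compound 1. Among the compounds with values here, the only measured step at this place is the large one a 12-fold lower number from compound 1 to compound 2 (1.07 log units; beyond the scatter) and it suggests a move back towards higher numbers, probably a smaller one. The expected change is a 5.5-fold higher number from compound 2 to compound 3 (0.74 log units; beyond the scatter) in this assay on this single comparison. Compound 3 is estimated at 40000 nM (expected range 10000 nM to 150000 nM).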

Compound 3, half-maximal effective concentration: 14000 nM
Beside the measured number, compound 3's estimate is 2.9-fold (0.46 log units) above it; low and high end bracket the measured number.
By their numbers in this assay, from the lowest: compounds 2 and 3 (each within the scatter of the next); then compound 1.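

In this assay the exchange on this oxygen gives a 1.9-fold higher number from compound 2 to compound 3 (0.28 log units; within the scatter) so 5-carboxypentyl and 1-methoxy-1-methylethyl cannot be told apart here. Within the six-carbon chain, carboxy in place of iodomethyl gives a 6.1-fold lower number from compound 1 to compound 3 (0.79 log units; beyond the scatter) so a long chain on this oxygen does not by itself hold the number at the level of compound 1. Nothing available explains either step.

Open, going by these compounds, is whether an amine or a methyl ester at the chain end, or a longer chain, would move the number beyond the scatter from that of compound 3.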